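Cyclopentyl for octyl on sulfur: cytotoxicity notes

The compounds below may be only part of what the source reports. "The series", "measured", "known", "first", "only" and "open" are said of these compounds alone.

Three compounds share the core under review in an ADME assay on MOLT-3 cells (Homo sapiens) for cytotoxicity, with a stated time of 7 days; a lower number here means that less compound is tolerated, a higher number that more compound is tolerated. Compound 1 (`CNc1nc(N)nc2c1ncn2/C=C1/CC1(CO)CO`) gives > 20000 nM in this assay as a limit of the assay, not a number. Compound 2 (`CCCNc1nc(N)nc2c1ncn2/C=C1/CC1(CO)CO`) has "not determined" (no result reported) as its entry and adds no reading. Compound 3 (`CCCCCCCCSc1nc(N)nc2c1ncn2/C=C1/CC1(CO)CO`) gives > 20000 nM as its entry, again only a limit.

The next structure is compound 4 (`Nc1nc(SC2CCCC2)c2ncn(/C=C3/CC3(CO)CO)c2n1`), which carries cyclopentyl in place of octyl on a sulfur and is otherwise unchanged. For the measured compounds named here, one measured step bears on this change (a step that the two limits leave unreadable from compound 1 to compound 3), and it has no readable size. The common ground in the series is a shared reading (the limit of > 20000 nM in this assay, at which 2 of the 3 values shown sit) and nothing finer. Compound 3 offers only a limit (> 20000 nM) as a starting point, so an expectation built on it stays loose. Going by the values given here, no measured step points to a shift in either direction in this assay for this exchange, and another limit is the likeliest report. The expected step (a number no higher from compound 3 to compound 4 (the limit leaves the size open)) is therefore none beyond the scatter. For compound 4 the estimate is 20000 nM as the expected value, with an expected range from 9000 nM to 40000 nM around it.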

Compound 4, half-maximal cytotoxic concentration: > 20000 nM
Compound 4 gave a limit, no number; the forecaster's own chance of this, stated with the estimate: 75%; the middle value sits exactly at the limit.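

The steps linking compound 4 to compound 3 and to compound 1 cannot be read in this assay, and the only common ground remains a limit, not a number: the limit of > 20000 nM in this assay, at which 3 of the 4 values shown sit.

The compounds shown leave open what number lies behind each limit, and whether cyclopentyl in place of octyl on a sulfur changes the reading in this assay at all.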